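Moving the methoxy group around the outer ring

A few compounds are considered here, and "the series" means these few. Any claim that something is new, unique, unknown or untested is made for them only; others in the source may bear on it.

Compound 2 `COc1ccc(-c2ccc(COCCCCCN3C[C@H](O)[C@@H](O)[C@H](O)[C@H]3CO)cc2)cc1` gives 25 nM in an assay on isolated protein for inhibition of ceramide glucosyltransferase (Homo sapiens) (on this read-out higher numbers stand for weaker inhibition and lower numbers for stronger inhibition), the lowest of the two numbers recorded so far. Compound 1 `Cc1cccc(-c2ccc(COCCCCCN3C[C@H](O)[C@@H](O)[C@H](O)[C@H]3CO)cc2)c1`, which carries a 3-methylphenyl instead, gives 100 nM in this assay; the step of a 4.0-fold lower number from compound 1 to compound 2 (0.60 log units; beyond the scatter) is the only measured one, and it changes both the kind of group and where it sits. Compound 3 `COc1cccc(-c2ccc(COCCCCCN3C[C@H](O)[C@@H](O)[C@H](O)[C@H]3CO)cc2)c1` differs from compound 2 by 3-methoxyphenyl in place of 4-methoxyphenyl on an aromatic carbon. Going by the values given here, no measured step isolates this change of position alone; the one step at hand points to the 4-methoxyphenyl as the better of the two ends, so some weakening is expected when the methoxy moves, though compound 1 at 100 nM gives a sense of how far that weakening might plausibly reach. For compound 3 the expected step is a 2.4-fold higher number from compound 2 to compound 3 (0.38 log units; beyond the scatter), giving an estimate of 60 nM in this assay, with a likely range from 20 nM to 180 nM.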

Compound 3, half-maximal inhibitory concentration: 150 nM
Compound 3: the middle estimate sits 2.5-fold (0.40 log units) below what was measured; the range from low to high includes it.
By their numbers in this assay, from the lowest: compound 2; then compounds 1 and 3 (each within the scatter of the next).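

Moving the methoxy group while keeping the same atoms gives a 6.0-fold higher number from compound 2 to compound 3 (0.78 log units; beyond the scatter) in this assay, so where this group sits on the outer ring matters on its own. Changing the group instead, with methoxy in place of methyl, gives a 1.5-fold higher number from compound 1 to compound 3 (0.18 log units; within the scatter), and this pair cannot be told apart. The earlier step from compound 1 to compound 2 changed both the group and its place, and these results suggest that its size may be tied more to the place than to the group, although nothing available explains the effect of position.

Going by these compounds, it remains open whether a methyl group would match the methoxy group in the position held by 4-methoxyphenyl. On these data alone, it is also open how an amine or a carboxylic acid would fare at either position.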